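Compound 3 without its (butylsulfonyl)amino group

The compounds below may be only part of what the source reports. "The series", "measured", "known", "first", "only" and "open" are said of these compounds alone.

In a functional assay for inhibition, with Homo sapiens as the target (on this read-out higher numbers stand for weaker inhibition and lower numbers for stronger inhibition), compound 1 (`O=C(NC[C@H](NS(=O)(=O)c1cccs1)C(=O)O)c1cc2sc(CCC3CCNCC3)cc2s1`) gives 13 nM, compound 2 (`O=C(NC[C@H](NS(=O)(=O)c1ccccc1)C(=O)O)c1cc2sc(CCC3CCNCC3)cc2s1`) gives 8 nM and compound 3 (`CCCCS(=O)(=O)N[C@@H](CNC(=O)c1cc2sc(CCC3CCNCC3)cc2s1)C(=O)O`) gives 10 nM. Compound 3 therefore sits within the scatter of both other compounds. The three differ only in the group on the sulfonyl sulfur, and the steps are small: a 1.6-fold lower number from compound 1 to compound 2 (0.21 log units; within the scatter), a 1.3-fold lower number from compound 1 to compound 3 (0.11 log units; within the scatter) and a 1.3-fold higher number from compound 2 to compound 3 (0.10 log units; within the scatter). Thiophen-2-yl, phenyl and butyl are thus not separated by these data.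

Compound 4 (`O=C(O)CCNC(=O)c1cc2sc(CCC3CCNCC3)cc2s1`) makes a larger change: hydrogen in place of (butylsulfonyl)amino on a saturated chain carbon bound to a carbonyl carbon and a saturated chain carbon. Hydrogen stands in place of (butylsulfonyl)amino on a saturated chain carbon bound to a carbonyl carbon and a saturated chain carbon. Among the measured compounds shown here, no measured compound lacks the whole group, so the flat steps above only loosely guide this one, and a real rise in the number in this assay, meaning weaker inhibition, seems more likely than none. The expected size is a 5.0-fold higher number from compound 3 to compound 4 (0.70 log units; beyond the scatter). For compound 4 the estimated value is 50 nM, with an expected range of 15 nM to 200 nM.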

Compound 4, half-maximal inhibitory concentration: 500 nM
Compound 4: the middle estimate sits 10-fold (1.00 log units) below what was measured; the measured number lies above the stated range.
By their numbers in this assay, from the lowest: compounds 2, 3 and 1 (each within the scatter of the next); then compound 4.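

In this assay, losing the whole group is a different matter from exchanging what sits on the sulfonyl sulfur: hydrogen in place of (butylsulfonyl)amino (a 50-fold higher number from compound 3 to compound 4 (1.70 log units; beyond the scatter)), of (phenylsulfonyl)amino (a 63-fold higher number from compound 2 to compound 4 (1.80 log units; beyond the scatter)) and of ((thiophen-2-yl)sulfonyl)amino (a 38-fold higher number from compound 1 to compound 4 (1.59 log units; beyond the scatter)) all give large steps towards weaker inhibition. Among the compounds shown here, the flat steps among compound 1, compound 2 and compound 3 therefore show only that these three groups on sulfur are not separated, not that the position can stay empty. Nothing at hand explains the loss.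

Which part of the group matters stays open, since compound 4 loses the sulfonyl and the nitrogen together. A plain amine or an acetylamino group on that carbon would separate the two.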